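The source may hold more compounds than are shown below. What is called first, only, known or untested is meant among the compounds shown, and "the series" means these compounds.

Going by the values given here, compound 2, with the structure `CC(C)C[C@H](N)CN(C(=O)[C@@H]1C[C@H]1c1ccccc1)c1ccc(C2=CCCCC2)cc1`, gives the higher of the two numbers known so far in a functional assay for agonist activity at G protein-coupled receptor 88 (Homo sapiens), read by HTRF and cAMP accumulation; a higher number here means that more compound is needed for the effect, a lower number that less compound is needed: compound 2 gives 1200 nM, while compound 1, with the structure `CC(C)C[C@@H](N)CN(C(=O)[C@@H]1C[C@H]1c1ccccc1)c1ccc(-c2ccccc2)cc1`, gives 1.8 nM, a difference well beyond the usual scatter. Compound 3, with the structure `CC(C)C[C@H](N)CN(C(=O)[C@@H]1C[C@H]1c1ccccc1)c1ccc(-c2cccc(F)c2)cc1`, has not yet been tested. It differs from compound 2 by one change: 3-fluorophenyl in place of cyclohex-1-en-1-yl on an aromatic carbon. Since compound 1 carries a phenyl at that position and gives 1.8 nM, compound 3 is expected to need less material than compound 2, a step estimated at an 8.0-fold lower number from compound 2 to compound 3 (0.90 log units; beyond the scatter). The value expected for compound 3 in this assay is 150 nM, with a range from 10 nM to 1500 nM.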

Compound 3, half-maximal effective concentration: 2100 nM
Compound 3: middle estimate off by 14-fold (1.15 log units), on the low side, outside the stated range (above it).
By their numbers in this assay, from the lowest: compound 1; then compounds 2 and 3 (each within the scatter of the next).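

In this assay the step is a 1.8-fold higher number from compound 2 to compound 3 (0.24 log units; within the scatter), so with 3-fluorophenyl in place of cyclohex-1-en-1-yl the two values cannot be told apart. In this pair, an aromatic ring at this position does not by itself give a low number. Nothing at hand gives a reason for this. Compound 1 differs from compound 3 in more than one place, including the arrangement at the carbon bearing the amine, so its low number cannot be assigned to either difference. Going by these compounds, what a pyridyl ring or a carboxylic acid would do at this position stays open.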